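The compounds below may be only part of what the source reports. "The series", "measured", "known", "first", "only" and "open" are said of these compounds alone.

Working notes on the group carried on a saturated chain carbon bound to an aromatic nitrogen. In a functional assay on MV4-11 cells (Homo sapiens) for antiproliferative activity, read by luminescence and CellTiter-Glo, with a stated time of 72 h (on this read-out higher numbers stand for weaker inhibition and lower numbers for stronger inhibition), compound 3 `CNc1cc(-c2ccc3cnn(Cc4ccc(C(F)(F)F)cc4)c3c2)cn(C)c1=O` gives 4370 nM and sits level with compound 1 `CNc1cc(-c2ccc3cnn(Cc4ccc(OC)cc4)c3c2)cn(C)c1=O` at 2700 nM within the scatter (a 1.6-fold higher number from compound 1 to compound 3 (0.21 log units; within the scatter)). Compound 2 `CNc1cc(-c2ccc3cnn(Cc4ccc(F)c([N+](=O)[O-])c4)c3c2)cn(C)c1=O` stands well apart at 130 nM (a 34-fold higher number from compound 2 to compound 3 (1.53 log units; beyond the scatter)).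

Compound 4 `CNc1cc(-c2ccc3cnn(CC4CCCCC4)c3c2)cn(C)c1=O` is still unmeasured and differs from compound 3 as follows (cyclohexyl in place of 4-(trifluoromethyl)phenyl on a saturated chain carbon bound to an aromatic nitrogen): cyclohexyl in place of 4-(trifluoromethyl)phenyl on a saturated chain carbon bound to an aromatic nitrogen. Going by the values given here, no measured step swaps an aromatic ring for a non-aromatic one, so the evidence is indirect. The exchange of methoxy for trifluoromethyl between compound 1 and compound 3 stayed within the scatter. Both large steps involve the 4-fluoro-3-nitrophenyl group of compound 2, including the drop in the number on introducing it (a 21-fold lower number from compound 1 to compound 2 (1.32 log units; beyond the scatter)). Compound 4 lacks that group, and no move beyond the scatter is expected in this assay. The expected step is small (a 1.2-fold lower number from compound 3 to compound 4 (0.10 log units; within the scatter)). The untested ring change leaves the range wide. For compound 4 the estimated value is 3500 nM, with an expected range from 1000 nM to 10000 nM.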

Compound 4, half-maximal inhibitory concentration: 2690 nM
Compound 4: middle estimate off by 1.3-fold (0.11 log units), on the high side; low and high end bracket the measured number.
By their numbers in this assay, from the lowest: compound 2; then compounds 4, 1 and 3 (each within the scatter of the next).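

In this assay, cyclohexyl on the saturated chain carbon bound to an aromatic nitrogen stays within the scatter of both 4-(trifluoromethyl)phenyl (a 1.6-fold lower number from compound 3 to compound 4 (0.21 log units; within the scatter)) and 4-methoxyphenyl (a 1.0-fold lower number from compound 1 to compound 4 (0.00 log units; within the scatter)), so among these compounds an aromatic ring at this position is not required to hold this level. The large separation remains tied to the 4-fluoro-3-nitrophenyl group, now also against a non-aromatic ring (a 21-fold higher number from compound 2 to compound 4 (1.32 log units; beyond the scatter)), and compounds 1, 3 and 4 form one level from which only compound 2 departs. No measurement is available that bears on what lies behind either the level or the separation.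

Open, going by these compounds, is which part of the 4-fluoro-3-nitrophenyl group carries the separation: a phenyl ring with only the nitro group or only the fluorine, or one with a nitrile or a carboxylic acid in place of the nitro group, could each divide it. Also open, on these data alone, is whether a piperidine ring, an amine or a longer chain in place of cyclohexyl would stay at the level of compound 4.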